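Working notes on solubility in the shared core series

The source may hold more compounds than are shown below. What is called first, only, known or untested is meant among the compounds shown, and "the series" means these compounds.

Measured compounds:
compound 1, `CNC(=O)c1cc(C(=O)NC2CC2)cn(Cc2cccc3cc[nH]c23)c1=O`, >= 144 ug/mL
compound 2, `CNC(=O)c1cc(C(=O)NCCOC)cn(Cc2ccccc2)c1=O`, >= 164 ug/mL

In a physicochemical assay for solubility (a higher number here means a more soluble compound, a lower number a less soluble compound), compound 1 gives >= 144 ug/mL, which is a limit of the assay rather than a number. Compound 2 gives >= 164 ug/mL in this assay, likewise a limit. Going by the values given here, for compound 1 the standing is thus a limit only, at the limit of >= 144 ug/mL in this assay, at which 1 of the 2 values shown sits, and the one further value shown sits at the other limit, (the limit of >= 164 ug/mL in this assay, at which 1 of the 2 values shown sits). With no numbers, nothing can be said of order or change between compound 1 and compound 2.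

Compound 3, `CNC(=O)c1cc(C(=O)NC2CC2)cn(Cc2cccc3cn[nH]c23)c1=O`, is not yet measured in this assay. It differs from compound 1 in one place: 1H-indazol-7-yl in place of 1H-indol-7-yl on a saturated chain carbon bound to an aromatic nitrogen.

Among the compounds with values here, no step between measured compounds is available. The expected change, a step that the limit leaves unreadable from compound 1 to compound 3, is none beyond the scatter, expected because only a limit is known for compound 1 >= 144 ug/mL. Compound 3 is therefore estimated at 150 ug/mL in this assay, within 60 ug/mL to 350 ug/mL, and most likely reported again as a limit.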

Compound 3, solubility: >= 181 ug/mL
Compound 3: no number, only a limit (the forecaster's own chance of this, stated with the estimate: 65%); middle value at least 1.2-fold (0.08 log units) from the limit.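

In this assay compound 3 gives >= 181 ug/mL as a limit. Going by these compounds alone, compound 1 also stands only at a limit, so no step from compound 1 to compound 3 can be read. Going by these compounds, whether 1H-indazol-7-yl in place of 1H-indol-7-yl changes solubility at all remains open.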